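Cap-group swap on the hydroxamate series: nitro for methoxy

The source may report more compounds than this note shows. Statements on the series, on what has been measured and on what is new or still open speak of the compounds shown alone.

Of the compounds shown here, two have a number so far. Compound 1 `COc1ccc(Oc2ccc3nc(/C=C/C(=O)NO)ccc3c2)cc1` gives 20.7 nM in an assay on isolated protein for inhibition of protein deacetylase HDAC6 (Homo sapiens), read by fluorescence (on this read-out higher numbers stand for weaker inhibition and lower numbers for stronger inhibition), the lowest of the two numbers shown. Compound 2 `COc1cc(Oc2ccc3nc(/C=C/C(=O)NO)ccc3c2)cc(OC)c1OC` gives 26.5 nM in this assay; the gap to compound 1 lies within the scatter, so nothing separates the two on this read-out. For the measured compounds named here, no step between measured compounds with a single change is available.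

Compound 3 `O=C(/C=C/c1ccc2cc(Oc3ccc([N+](=O)[O-])cc3)ccc2n1)NO` has not been measured. It differs from compound 1 by nitro in place of methoxy on an aromatic carbon, a nitro in place of methoxy on an aromatic carbon. Going by the values given here, the only comparison at hand, compound 1 against compound 2, shows that a change at this end of the molecule barely moves the number. The expected step is therefore small, with no direction beyond the scatter: a 1.2-fold higher number from compound 1 to compound 3 (0.08 log units; within the scatter) is the estimate. Compound 3 is expected to give 25 nM in this assay, between 10 nM and 65 nM.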

Compound 3, half-maximal inhibitory concentration: 51.4 nM
For compound 3 the middle estimate is 2.1-fold (0.31 log units) below the measured one, and the stated range covers the measured number.
By their numbers in this assay, from the lowest: compounds 1, 2 and 3 (each within the scatter of the next, the first and the last beyond it).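

Nitro in place of methoxy, on an aromatic carbon para to a large group, gives the first single-change step of the series: a 2.5-fold higher number from compound 1 to compound 3 (0.39 log units; beyond the scatter) in this assay. This position is therefore not indifferent to the group it carries, which compound 1 and compound 2 alone could not establish, as they differ in more than one place. Nothing at hand bears on why the number rises with this change.

For the compounds shown here, the single pair leaves open whether the step belongs to the nitro group as such or to the loss of methoxy; an amine or a fluorine on the same carbon would help to separate the two. It also leaves open whether the same swap would give a similar step with other groups elsewhere on the shared core.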